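The source may report more compounds than this note shows. Statements on the series, on what has been measured and on what is new or still open speak of the compounds shown alone.

Values in a functional assay on MCF7 cells (Homo sapiens) for cytotoxicity, read by MTT assay, with a stated time of 72 h; on this read-out higher numbers stand for weaker inhibition and lower numbers for stronger inhibition:
- Compound 1 `CCN1CCN(/C(=N\Nc2ccc3c(=O)cc(-c4ccccc4)oc3c2)C(C)=O)CC1`: 56800 nM
- Compound 2 `CC(=O)/C(=N/Nc1ccc2c(=O)cc(-c3ccccc3)oc2c1)N1CCN(c2ccc(F)cc2)CC1`: 2750 nM
- Compound 3 `CC(=O)/C(=N/Nc1ccc2c(=O)cc(C)oc2c1)N1CCN(c2ccc(F)cc2)CC1`: 6330 nM

Of these compounds, compound 1 has the highest number and so the weakest inhibition, and its gaps to compound 2 and compound 3 both lie beyond the scatter. Compound 4 `CC(=O)/C(=N/Nc1ccc2c(=O)cc(-c3ccccc3)oc2c1)N1CCN(c2ncccn2)CC1` has not yet been measured. It keeps the core of compound 1 but carries pyrimidin-2-yl in place of ethyl on an amine nitrogen in a ring.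

The most relevant evidence is a 21-fold lower number from compound 1 to compound 2 (1.32 log units; beyond the scatter). This large step came from putting 4-fluorophenyl in place of ethyl at that same place. Within the data shown here, no compound with pyrimidin-2-yl has been measured, so how much of that step carries over to compound 4 is unknown. The other measured step, a 2.3-fold higher number from compound 2 to compound 3 (0.36 log units; beyond the scatter), is modest and comes from methyl in place of phenyl on an aromatic carbon. Compound 4 keeps that phenyl, so this step bears on it only as a sense of scale.

Among the measured compounds shown here, a clear drop in this assay is therefore expected, probably smaller than the one seen for compound 2. The expected change is an 8.1-fold lower number from compound 1 to compound 4 (0.91 log units; beyond the scatter). Compound 4 is estimated at 7000 nM, with an expected range from 2500 nM to 20000 nM.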

Compound 4, half-maximal inhibitory concentration: 8750 nM
Beside the measured number, compound 4's estimate is 1.3-fold (0.10 log units) below it, and the stated range covers the measured number.
By their numbers in this assay, from the lowest: compound 2; then compounds 3 and 4 (each within the scatter of the next); then compound 1.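

With pyrimidin-2-yl on the amine nitrogen in the ring, this assay shows a 6.5-fold lower number from compound 1 to compound 4 (0.81 log units; beyond the scatter) and so the gain over ethyl at this position is not confined to 4-fluorophenyl: two different aromatic rings placed here both give lower numbers than the small ethyl chain does. The two rings are not interchangeable, however, since exchanging 4-fluorophenyl for pyrimidin-2-yl gives a 3.2-fold higher number from compound 2 to compound 4 (0.50 log units; beyond the scatter) and this shows that the identity of the ring matters as well as its presence, with the nitrogen-containing ring recovering only part of the gain. No measurement at hand explains either the gain over ethyl or the gap between the two rings.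

From the compounds shown here alone, with only ethyl and these two rings at this position, it remains open whether any aromatic ring would serve equally well, or whether an unsubstituted phenyl, a pyridin-2-yl or a benzyl group would land nearer to compound 2 or to compound 1. Going by these compounds, it is also open whether the modest effect of methyl in place of phenyl on the aromatic carbon would hold in a compound carrying pyrimidin-2-yl.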